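The source may hold more compounds than are shown below. What is called first, only, known or untested is meant among the compounds shown, and "the series" means these compounds.

Measured so far:
compound 1 `CC1=C(O)[C@@H](C/C(C)=C\CCC(C)/C=C/C=C(\C)CCCc2ccoc2)OC1=O`: > 30 ug/mL
compound 2 `CC1=C(O)[C@@H](C/C(C)=C\CCC(C)/C=C/C/C(C)=C/CCc2ccoc2)OC1=O`: 16.3 ug/mL

Compound 1 stands at the limit of a functional assay on SK-MEL-2 cells (Homo sapiens) for cytotoxicity; on this read-out lower numbers stand for an effect already at smaller amounts and higher numbers for an effect only at larger amounts of compound: in this assay compound 1 gives > 30 ug/mL, which is a limit of the measurement and not a number (the limit of > 30 ug/mL in this assay, at which 1 of the 2 values shown sits). Compound 2 gives 16.3 ug/mL in this assay. Compound 3 `CC1=C(O)[C@H](C/C(C)=C\CCC(C)/C=C\C=C(\C)CCCc2ccoc2)OC1=O` has the same atoms and bonds as compound 1; the difference is the two compounds have the same atoms and bonds; at least one stereo element is drawn with a configuration in one of them and without one in the other: 3 of 5 stereo elements differ; a stereocentre at a saturated ring carbon is drawn R in compound 1 and S in compound 3; a double bond is drawn E in compound 1 and Z in compound 3; a double bond is drawn E in compound 1 and Z in compound 3. No measured step of this kind is shown, so neither size nor direction of the change is known. Compound 3 is expected to give 25 ug/mL in this assay, within 8 ug/mL to 60 ug/mL. The expected step of an at least 1.2-fold lower number from compound 1 to compound 3 (0.07 log units; that floor lies within the scatter) is modest, and the result may again be only a limit.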

Compound 3, concentration for half-maximal effect: 7.78 ug/mL
The estimate for compound 3 lay 3.2-fold (0.51 log units) above the measured number, outside the stated range (below it).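

In this assay, a change in stereo elements alone, with no atom or bond altered, gives an at least 3.8-fold lower number from compound 1 to compound 3 (0.58 log units; beyond the scatter). So the drawn arrangement in space matters here, not only which atoms are present. For compound 1, > 30 ug/mL is a limit and not a number: the limit of > 30 ug/mL in this assay, at which 1 of the 3 values shown sits.

The compounds shown leave open which change carries this step, the stereocentre at the saturated ring carbon or one of the two double bonds: the fact that one of compounds 1 and 3 is drawn with a defined configuration and the other without, at the place where they differ They also leave open how a longer chain or an amine would read in this assay.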